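Side-chain amine change on the shared core: compound 2 to compound 3

A few compounds are considered here, and "the series" means these few. Any claim that something is new, unique, unknown or untested is made for them only; others in the source may bear on it.

Of the compounds shown here, two have numbers so far. Compound 1 `O=c1sc2cc(S(=O)(=O)c3ccccc3)ccc2n1CCN1CCCCC1` gives 11% in an assay on HEK293 cells for displacement of a labelled ligand from 5-hydroxytryptamine receptor 6 (Homo sapiens), read by radioligand binding, with a stated time of 60 min, tested at 100 nM; a higher number here means more inhibition at the concentration tested (going by the name of the read-out), a lower number less inhibition. Compound 2 `CN(C)CCn1c(=O)sc2cc(NS(=O)(=O)c3ccccc3)ccc21` gives 5% in this assay. This is the lower of the two numbers, but the value of compound 1 lies within the usual scatter of it, so no order between the two can be read. Going by the values given here, compound 1 and compound 2 differ in more than one place, and no single step between them is available.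

Compound 3 `O=c1sc2cc(NS(=O)(=O)c3ccccc3)ccc2n1CCN1CCCCC1` has not been measured. It differs from compound 2 in one place: piperidin-1-yl in place of dimethylamino on a saturated chain carbon, two bonds along the chain from an aromatic nitrogen. The same 2-(piperidin-1-yl)ethyl chain is present in compound 1, which gives 11% in this assay, also a small number. Both measured compounds show little inhibition, and nothing in the data points to a step beyond the scatter for this change.

Compound 3 is expected to give 10% in this assay, with a range from 0% to 30%. The expected step of a number 5 percentage points higher from compound 2 to compound 3 (within the scatter) is within the scatter.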

Compound 3, a percentage reported as inhibition, at one concentration (the size of the read-out at that concentration, not a potency): 6%
Compound 3: the middle estimate sits 4 percentage points above what was measured, and the stated range covers the measured number.
By their numbers in this assay, from the lowest: compounds 2, 3 and 1 (each within the scatter of the next).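

In this assay, piperidin-1-yl in place of dimethylamino on a saturated chain carbon, two bonds along the chain from an aromatic nitrogen, gives a number 1 percentage points higher from compound 2 to compound 3 (within the scatter). Going by these compounds alone, this is the first step that changes one place only, and it shows that this exchange of the side-chain amine, from an open-chain group to a six-membered non-aromatic ring, does not produce a difference that can be read from the scatter. No measurement is available that would explain this result.

Going by these compounds, the step is read only among compounds with small numbers at one tested concentration, so it remains open whether the same exchange would also leave the number unchanged on a compound showing stronger inhibition. On these data alone, it also remains open whether a morpholin-4-yl or pyrrolidin-1-yl group at the end of the same chain, or a longer chain carrying either piperidin-1-yl or dimethylamino, would give a step beyond the scatter.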